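The source may hold more compounds than are shown below. What is called first, only, known or untested is meant among the compounds shown, and "the series" means these compounds.

Measured compounds:
Compound 1, `C=C1[C@@H](OC(C)=O)C[C@@H]2[C@](C)(COC=O)[C@H](OC(C)=O)CC[C@@]2(C)[C@@H]1C[C@@H](Nc1cccc(F)c1)C1=CCOC1=O`, gives 14100 nM in a functional assay on MCF7 cells (Homo sapiens) for cytotoxicity, read by sulforhodamine B assay; on this read-out higher numbers stand for weaker inhibition and lower numbers for stronger inhibition.
Compound 2, `C=C1[C@@H](OC(C)=O)C[C@@H]2[C@](C)(COC=O)[C@H](OC(C)=O)CC[C@@]2(C)[C@@H]1C[C@@H](Nc1ccccc1F)C1=CCOC1=O`, gives 16400 nM in this assay.
Compound 3, `C=C1[C@@H](OC(C)=O)C[C@@H]2[C@](C)(CO[Si](C)(C)C(C)(C)C)[C@H](OC(C)=O)CC[C@@]2(C)[C@@H]1C[C@@H](Nc1ccccc1F)C1=CCOC1=O`, gives 2930 nM in this assay.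

Compounds 1 and 2 share one core and differ only in the aryl group on the amine nitrogen, as counted in 3-fluorophenyl in place of 2-fluorophenyl on an amine nitrogen; the step of a 1.2-fold lower number from compound 2 to compound 1 (0.07 log units; within the scatter) is within the scatter, so the two values cannot be told apart. Compound 3 carries a different core, and how the cores differ is counted in a group of 7 heavy atoms (6 carbon, 1 silicon; no ring) in place of a group of 2 heavy atoms (1 carbon, 1 oxygen; no ring), on an oxygen on a saturated carbon; this change made the step of a 5.6-fold lower number from compound 2 to compound 3 (0.75 log units; beyond the scatter), and compound 3 gives the strongest inhibition of the three measured compounds, its steps to both others lying beyond the scatter.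

Compound 4, `C=C1[C@@H](OC(C)=O)C[C@@H]2[C@](C)(CO[Si](C)(C)C(C)(C)C)[C@H](OC(C)=O)CC[C@@]2(C)[C@@H]1C[C@@H](Nc1cccc(F)c1)C1=CCOC1=O`, has not been measured. It differs from compound 3 by 3-fluorophenyl in place of 2-fluorophenyl on an amine nitrogen, and the place line reads the same as for the change from compound 2 to compound 1, so this is the same change made on the core of compound 3. This change occurs twice among the compounds shown, and its one measured instance is a 1.2-fold lower number from compound 2 to compound 1 (0.07 log units; within the scatter).

The step from compound 3 to compound 4 is expected to be a 1.2-fold lower number from compound 3 to compound 4 (0.07 log units; within the scatter), resting on compound 2 and compound 1, whose step a 1.2-fold lower number from compound 2 to compound 1 (0.07 log units; within the scatter) lies within the scatter. Compound 4 is therefore estimated at 2500 nM in this assay, with a likely range from 1000 nM to 6000 nM.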

Compound 4, half-maximal inhibitory concentration: 3820 nM
Estimate against measurement, compound 4: 1.5-fold (0.18 log units) below, within the range that was stated.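

The step from 2-fluorophenyl to 3-fluorophenyl on the amine nitrogen, made on the core of compound 3, gives a 1.3-fold higher number from compound 3 to compound 4 (0.12 log units; within the scatter) in this assay, and set beside the same change on the other core it reads: the same change on two cores in this assay, a 1.2-fold lower number (0.07 log units; within the scatter) from compound 2 to compound 1 and a 1.3-fold higher number (0.12 log units; within the scatter) from compound 3 to compound 4, 1.5-fold (0.18 log units) apart, within the scatter of two such steps. The group of 7 heavy atoms (6 carbon, 1 silicon) in place of the group of 2 heavy atoms (1 carbon, 1 oxygen), on an oxygen on a saturated carbon, gives a 3.7-fold lower number from compound 1 to compound 4 (0.57 log units; beyond the scatter) with the 3-fluorophenyl group in place, and it holds up beside the step seen with the 2-fluorophenyl group: the same change on two cores in this assay, a 5.6-fold lower number (0.75 log units; beyond the scatter) from compound 2 to compound 3 and a 3.7-fold lower number (0.57 log units; beyond the scatter) from compound 1 to compound 4, 1.5-fold (0.18 log units) apart, within the scatter of two such steps. In these four compounds, then, each change reads the same on both cores, with the aryl swap leaving the two values indistinguishable and the oxygen change staying beyond the scatter, but each comparison rests on a single pair of steps and says nothing about cores outside this set.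

The compounds shown leave open whether an unsubstituted phenyl or a chlorophenyl on the amine nitrogen would read like the two fluorophenyl groups. They also leave open how a free hydroxyl or a benzyl ether on that oxygen would compare with the group of 7 heavy atoms.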